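Solubility notes: amide tail swap on the shared core

The source may hold more compounds than are shown below. What is called first, only, known or untested is meant among the compounds shown, and "the series" means these compounds.

Measured so far:
compound 1 `CN1CCCC(NS(=O)(=O)c2ccccc2Nc2cc(-c3ccc4ccn(C)c4c3)c3nccnc3c2)C1`: 9 ug/mL
compound 2 `Cn1ccc2ccc(-c3cc(Nc4cnccc4C(=O)NCc4cncnc4)cc4nccnc34)cc21`: 233 ug/mL

In a physicochemical assay for solubility, read by spectrophotometry, measured as kinetic solubility, at pH 8, tested at 500 uM (on this read-out lower numbers stand for lower solubility and higher numbers for higher solubility), compound 2 stands highest of the two numbers shown, with compound 1 at 9 ug/mL well beyond the scatter below it; the two differ in more than one place, so no single step connects them. Going by these compounds, compound 3 `Cn1ccc2ccc(-c3cc(Nc4cnccc4C(=O)NCC4COCCN4)cc4nccnc34)cc21` is still untested. Against compound 2 the change is morpholin-3-yl in place of pyrimidin-5-yl on a saturated chain carbon bound to an amide-type nitrogen. Since compound 2 already sits at the top of what has been seen, the expected step from compound 2 to compound 3 is none beyond the scatter, a 1.0-fold lower number from compound 2 to compound 3 (0.01 log units; within the scatter). Compound 3 is therefore estimated at 230 ug/mL, within 140 ug/mL to 250 ug/mL.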

Compound 3, solubility: 239 ug/mL
The estimate for compound 3 lay 1.0-fold (0.02 log units) below the measured number; low and high end bracket the measured number.
By their numbers in this assay, from the lowest: compound 1; then compounds 2 and 3 (each within the scatter of the next).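

In this assay, the saturated chain carbon bound to an amide-type nitrogen now has its first one-place comparison: morpholin-3-yl in place of pyrimidin-5-yl gives a 1.0-fold higher number from compound 2 to compound 3 (0.01 log units; within the scatter). Here a six-membered aromatic ring and a six-membered non-aromatic ring, the latter bringing a hydrogen-bond donor, read alike. Nothing available explains this result.

Going by these compounds, whether an open-chain amine or a carboxylic acid at this place would move the number remains open, as does the effect of a longer chain carrying the morpholin-3-yl. Compound 1 differs from both in more than one place, so its gap cannot be assigned to any single change.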